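The source may hold more compounds than are shown below. What is called first, only, known or untested is meant among the compounds shown, and "the series" means these compounds.

In an ADME assay on MDBK cells (Bos taurus) for cytotoxicity, read by MTT assay, with a stated time of 96 h (a lower number here means that less compound is tolerated, a higher number that more compound is tolerated), compound 1 (`FC(F)(F)c1cccc(NC(=S)Nc2ccc(Cl)cc2)c1`) gives 17000 nM and compound 3 (`Fc1ccc(NC(=S)Nc2cccc(C(F)(F)F)c2)cc1Cl`) gives 11000 nM while compound 2 (`CCCC[C@H]1CC[C@H](c2ccc(NC(=S)Nc3cccc(C(F)(F)F)c3)cc2)CC1`) gives 10000 nM as its half-maximal cytotoxic concentration. Compound 2 stands within the scatter of both other compounds, so these numbers set no order among them. Compound 4 (`FC(F)(F)c1cccc(NC(=S)Nc2ccccc2)c1`) has not yet been measured and differs from compound 2 as follows: hydrogen in place of 4-butylcyclohexyl on an aromatic carbon. Going by the values given here, only one measured step involves this group: a 1.7-fold lower number from compound 1 to compound 2 (0.23 log units; within the scatter) with 4-butylcyclohexyl in place of chloro on an aromatic carbon, and it lies within the scatter. Among the compounds with values here, no measured pair shows hydrogen at that place, so this evidence is indirect. In this assay no step beyond the scatter is therefore expected. The expected step of a 1.5-fold higher number from compound 2 to compound 4 (0.18 log units; within the scatter) is small and stays within the scatter. For compound 4 the estimate is 15000 nM and the expected range runs from 7000 nM to 35000 nM as the likely span.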

Compound 4, half-maximal cytotoxic concentration: 49000 nM
Estimate against measurement, compound 4: 3.3-fold (0.51 log units) below; the measured number lies above the stated range.
By their numbers in this assay, from the lowest: compounds 2, 3 and 1 (each within the scatter of the next); then compound 4.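

In this assay, this place on the aromatic carbon shows its first steps beyond the scatter once it carries only hydrogen: hydrogen in place of 4-butylcyclohexyl gives a 4.9-fold higher number from compound 2 to compound 4 (0.69 log units; beyond the scatter), and hydrogen in place of chloro gives a 2.9-fold higher number from compound 1 to compound 4 (0.46 log units; beyond the scatter). The earlier step, a 1.7-fold lower number from compound 1 to compound 2 (0.23 log units; within the scatter), suggested that the group at this place made no difference, but these steps show that the clear divide among the compounds shown lies between hydrogen and either group, not between chloro and 4-butylcyclohexyl. No supporting evidence accounts for this divide.

The compounds shown leave open whether a small group such as methyl or methoxy at this place would give a number near that of hydrogen or near those of chloro and 4-butylcyclohexyl. They also leave open where an amine or a carboxylic acid there would fall.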